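The source may hold more compounds than are shown below. What is called first, only, known or untested is meant among the compounds shown, and "the series" means these compounds.

Of the compounds shown here, two built on the shared core have so far been measured in a physicochemical assay for lipophilicity, measured as octanol-water partition; a higher number here means a more lipophilic compound, a lower number a more polar compound. Compound 1, `O=C(COc1cccc2ccccc12)N/N=C/c1cccc(O)c1`, gives 3.73 in this assay. Compound 2, `C/C(=N\NC(=O)COc1cccc2ccccc12)c1ccc(O)cc1`, gives 4.44 in this assay, the higher of the two values; its distance from compound 1 lies beyond the usual scatter, so compound 2 stands as the more lipophilic of the pair.

The next compound, compound 3, `C/C(=N\NC(=O)COc1cccc2ccccc12)c1ccccc1Br`, has not yet been measured. It differs from compound 2 in a single place: 2-bromophenyl in place of 4-hydroxyphenyl on a carbon with a double bond to nitrogen. The leaving group brings one hydrogen-bond donor and one hydrogen-bond acceptor; the entering group brings none of either, and a bromine in place of the oxygen.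

Within the data shown here, no step between two measured compounds shows an exchange of this kind, so the expectation rests on the change itself. A rise in this assay is expected, of a size well beyond the scatter, with an expected step of a number 1.46 log units higher from compound 2 to compound 3 (beyond the scatter). For compound 3 the estimated value in this assay is 5.9, within a range from 5.3 to 6.5.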

Compound 3, partition coefficient: 4.44
For compound 3 the middle estimate is 1.46 log units above the measured one; the measured number lies below the stated range.
By their numbers in this assay, from the lowest: compound 1; then compounds 2 and 3 (each within the scatter of the next).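

In this assay, among these compounds, replacing 4-hydroxyphenyl with 2-bromophenyl on a carbon with a double bond to nitrogen gives no change at the digits printed from compound 2 to compound 3 (within the scatter), the first direct reading of an exchange at this position. The entering group has neither of the hydrogen-bond features counted on the leaving group, yet the two compounds cannot be told apart in this assay, so in this pair those counts alone do not settle the reading. The exchange alters two things at once, the atom attached to the ring (oxygen or bromine) and where it sits in the name of the group, and no measurement shown here accounts for the result.

A plain phenyl group at this carbon would provide a common reference, showing whether 4-hydroxyphenyl and 2-bromophenyl each shift the value from that reference or whether neither does. On these data alone, it also remains open how this assay would respond to a phenyl ring carrying an amine or a carboxylic acid, or to a longer chain in place of the ring at this same carbon.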